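Toward compound 4: a pyrimidinyl amide from a difluorophenyl one

A few compounds are considered here, and "the series" means these few. Any claim that something is new, unique, unknown or untested is made for them only; others in the source may bear on it.

Measured so far:
compound 1, `COc1ccc2nc(C)cc(OCC(=O)Nc3cc(C)ccc3OC)c2c1`, 5.65
compound 2, `COc1ccc2nc(C)cc(OCC(=O)Nc3cc(C)c(F)c(C)c3)c2c1`, 5.5
compound 3, `COc1ccc2nc(C)cc(OCC(=O)Nc3cc(F)cc(F)c3)c2c1`, 5.13

In a physicochemical assay for lipophilicity, read by HPLC, in phosphate buffer, measured as chromatographic lipophilicity, at pH 7.4 (a lower number here means a more polar compound, a higher number a more lipophilic compound), compound 3 stands lowest of the three numbers. Its nearest neighbour is compound 2, and the step of a number 0.37 log units lower from compound 2 to compound 3 (beyond the scatter) lies beyond the scatter; the step of a number 0.52 log units lower from compound 1 to compound 3 (beyond the scatter) is larger still. The step of a number 0.15 log units lower from compound 1 to compound 2 (within the scatter) is within the scatter, so only compound 3 sets itself apart from the others.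

Compound 4 is `COc1ccc2nc(C)cc(OCC(=O)Nc3ccncn3)c2c1`. It differs from compound 3 in one place: pyrimidin-4-yl in place of 3,5-difluorophenyl on an amide-type nitrogen

Every measured step exchanges one carbon-only aromatic ring for another on the amide-type nitrogen, and the largest of them, a number 0.52 log units lower from compound 1 to compound 3 (beyond the scatter), is only modest. The change to compound 4 is of another kind: a ring with two hetero atoms and two hydrogen-bond acceptors enters where a ring of carbon only with two fluorine atoms leaves. Within the data shown here, no measured pair shows such an exchange, so the size of the step rests on the direction of the measured ones and on the fact that compound 3 already sits lowest. The step is expected downward and larger than any measured one, a number 1.43 log units lower from compound 3 to compound 4 (beyond the scatter). Compound 4 is therefore estimated at 3.7, within a range from 3 to 4.4.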

Compound 4, distribution coefficient: 2.53
Compound 4: middle estimate off by 1.17 log units, on the high side; measured number below the stated range.
By their numbers in this assay, from the lowest: compound 4; then compound 3; then compounds 2 and 1 (each within the scatter of the next).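

At the place on the amide-type nitrogen whose other neighbour is the carbonyl carbon, the exchanges among carbon-only rings had moved this assay only modestly at most, whereas pyrimidin-4-yl in place of 3,5-difluorophenyl gives a number 2.60 log units lower from compound 3 to compound 4 (beyond the scatter), a large step. Among these compounds, the same kind of exchange reads as a number 2.97 log units lower from compound 2 to compound 4 (beyond the scatter) and as a number 3.12 log units lower from compound 1 to compound 4 (beyond the scatter), so the position can carry far more of the range of this read-out than the earlier compounds showed, and the direction holds whichever of the three carbon-only rings leaves. Nothing on hand accounts for the size of this drop.

The compounds shown include only one ring with hetero atoms, which leaves open whether the drop belongs to pyrimidin-4-yl as a whole or could be reached with only one of its ring nitrogens. They also leave open how far this assay would move with a longer chain carrying an amine or a carboxylic acid on the amide-type nitrogen in place of these rings.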